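Cyano on the anilide ring: cytotoxicity expectation

The source may report more compounds than this note shows. Statements on the series, on what has been measured and on what is new or still open speak of the compounds shown alone.

Compound 1 `Cc1cc(C#N)cc(C)c1Oc1ccnc(S(=O)(=O)CC(=O)Nc2ccccc2F)n1` holds the upper of the two numbers shown in an ADME assay on MT4 cells (Homo sapiens) for cytotoxicity, read by MTT assay, with a stated time of 4 days (a higher number here means that more compound is tolerated, a lower number that less compound is tolerated), at 28400 nM; compound 2 `Cc1cc(C#N)cc(C)c1Oc1ccnc(S(=O)(=O)CC(=O)Nc2cccc(Cl)c2)n1` gives 25400 nM, and a 1.1-fold lower number from compound 1 to compound 2 (0.05 log units; within the scatter). The change to compound 3 `Cc1cc(C#N)cc(C)c1Oc1ccnc(S(=O)(=O)CC(=O)Nc2ccc(C#N)cc2F)n1` is cyano in place of hydrogen on an aromatic carbon. Going by the values given here, the only measured step swaps one substituted phenyl for another on the amide nitrogen and stays within the scatter; no measured step adds a cyano group to this ring. The expected step in this assay is therefore a 1.1-fold lower number from compound 1 to compound 3 (0.06 log units; within the scatter), none beyond the scatter. Compound 3 is estimated at 25000 nM, ranging from 10000 nM to 60000 nM.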

Compound 3, half-maximal cytotoxic concentration: > 268000 nM
Compound 3 gave a limit, no number; the forecaster's own chance of this, stated with the estimate: 15%; middle value at least 10-fold (1.03 log units) away from the limit.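

In this assay, compound 3 carries a limit and not a number: the limit of > 268000 nM in this assay, at which 1 of the 3 values shown sits.

Cyano in place of hydrogen on this aromatic carbon, para to a large group and meta to a fluoro group, gives a shift beyond the scatter (an at least 9.4-fold higher number from compound 1 to compound 3 (0.97 log units; beyond the scatter)), while the earlier phenyl swap stayed within it. The change of the whole group on the amide nitrogen reads the same way (an at least 10-fold higher number from compound 2 to compound 3 (1.02 log units; beyond the scatter)).

From the compounds shown here alone, how far the shift extends remains open, as does whether it is specific to cyano. An amine or a carboxylic acid on the same carbon would test the latter.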